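The compounds below may be only part of what the source reports. "The series", "measured", "known", "first", "only" and "open" are said of these compounds alone.

Three compounds share one core, and they are compared in an ADME assay on J774 cells (Mus musculus, strain BALB/c) for cytotoxicity, read by resazurin assay, with a stated time of 72 h; a lower number here means that less compound is tolerated, a higher number that more compound is tolerated. Compound 1 `CC(/C=N/Nc1ccc([N+](=O)[O-])cc1)=N\NC(=O)c1ccccc1O` carries a 2-hydroxyphenyl on the carbonyl carbon, and in this assay compound 1 gives 29500 nM. Compound 2 `CC(/C=N/Nc1ccc([N+](=O)[O-])cc1)=N\NC(=O)c1ccccc1F` carries a 2-fluorophenyl in its place; in this assay compound 2 reaches only the limit, > 100000 nM. Compound 3 `CC(/C=N/Nc1ccc([N+](=O)[O-])cc1)=N\NC(=O)c1cccc(C)c1` carries a 3-methylphenyl there, and compound 3 also sits at the limit of this assay, > 100000 nM. Thus compound 3 stands at the upper end of what the numbers shown can tell, together with one other value, as the limit of > 100000 nM in this assay, at which 2 of the 3 values shown sit, records. The step of an at least 3.3-fold higher number from compound 1 to compound 3 (0.53 log units; beyond the scatter) is at least modest, as is the step of an at least 3.3-fold higher number from compound 1 to compound 2 (0.53 log units; beyond the scatter); the step that the two limits leave unreadable from compound 2 to compound 3 cannot be sized, since both ends are limits.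

Compound 4 `CC(/C=N/Nc1ccc([N+](=O)[O-])cc1)=N\NC(=O)c1ccc(Cl)cc1` differs from compound 3 by the change (4-chlorophenyl in place of 3-methylphenyl on a carbonyl carbon). Among the compounds with values here, no measured step makes exactly this change. Both compounds lacking the hydroxy sat at the limit, so the expectation for compound 4 is a number near that limit, with the step of a number no higher from compound 3 to compound 4 (the limit leaves the size open) expected to stay within the scatter. Compound 4 is therefore estimated at 100000 nM in this assay, in the range 35000 nM to 300000 nM.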

Compound 4, half-maximal cytotoxic concentration: 63900 nM
Compound 4: middle estimate off by 1.6-fold (0.19 log units), on the high side; measured number inside the range.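

Among the compounds without the hydroxy, compound 4 is the only one that gives a full number rather than a limit in this assay, so its 4-chlorophenyl on the carbonyl carbon puts a first sized value on this side of the series. The steps of an at least 1.5-fold lower number from compound 3 to compound 4 (0.19 log units; that floor lies within the scatter) and an at least 1.5-fold lower number from compound 2 to compound 4 (0.19 log units; that floor lies within the scatter) are only floors, so they show no change beyond the scatter, although the true size of each could be larger. Within the data shown here, with numbers now at both ends, the step of a 2.2-fold higher number from compound 1 to compound 4 (0.34 log units; beyond the scatter) gives a modest gap that can be sized between the 2-hydroxyphenyl and a group without the hydroxy, whereas the earlier steps from compound 1 gave only a lower bound.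

On these data alone, how far compound 2 and compound 3 truly stand from compound 4 stays open, as both remain limits and the steps between such limits cannot be read: the limit of > 100000 nM in this assay, at which 2 of the 4 values shown sit. As far as these compounds go, what an amine or a carboxylic acid on this phenyl would give also stays open, as does the effect of a longer chain between the carbonyl carbon and the ring.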